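Moving a Fluorine on a Shared Bis-sulfonamide Core

The source may report more compounds than this note shows. Statements on the series, on what has been measured and on what is new or still open speak of the compounds shown alone.

Measured so far in an assay for inhibition of liver carboxylesterase 1 (Homo sapiens), read by spectrophotometry; a lower number here means a stronger inhibitor, a higher number a weaker inhibitor:
compound 1 `O=S(=O)(Nc1ccc(NS(=O)(=O)c2cc(Cl)ccc2Cl)cc1)c1cc(Cl)ccc1Cl` gives > 100000 nM, a limit of the assay.
compound 2 `Cc1ccc(S(=O)(=O)Nc2ccc(NS(=O)(=O)c3ccc(F)cc3F)cc2)cc1` gives > 100000 nM, a limit of the assay.
compound 3 `O=S(=O)(Nc1cc(Br)c(NS(=O)(=O)c2ccc(Cl)cc2)cc1Br)c1ccc(Cl)cc1` gives > 100000 nM, a limit of the assay.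

Compound 2 therefore stands at a limit in this assay, with no number behind it, and the same is true of the other two compounds (the limit of > 100000 nM in this assay, at which 3 of the 3 values shown sit). Going by the values given here, no step between two measured compounds can be drawn from these values.

Compound 4 `Cc1ccc(S(=O)(=O)Nc2ccc(NS(=O)(=O)c3ccc(F)c(F)c3)cc2)cc1` differs from compound 2 in one place: 3,4-difluorophenyl in place of 2,4-difluorophenyl on a sulfonyl sulfur.

With nothing to go on but three limits, the expected step in this assay is none beyond the usual scatter, in either direction. The step that the limit leaves unreadable from compound 2 to compound 4 is expected to be flat. Compound 4 is estimated at 150000 nM, in a range from 50000 nM to 500000 nM, most likely reported again as a limit.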

Compound 4, inhibition constant: > 100000 nM
Compound 4: only a limit was reported; the forecaster's own chance of this, stated with the estimate: 85%; the middle value is on the limit's open side.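

No step can be read from compound 2 to compound 4, because both compounds sit at a limit of the assay: the limit of > 100000 nM in this assay, at which 4 of the 4 values shown sit.

From the compounds shown here alone, whether any change to the shared core would give a measurable number in this assay stays open.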